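Carbonyl substituent and half-life in the series

A few compounds are considered here, and "the series" means these few. Any claim that something is new, unique, unknown or untested is made for them only; others in the source may bear on it.

Measured in an ADME assay on S9 fraction from S9 cells (Zone of skin, Homo sapiens) for metabolic stability, read by HPLC, with a stated time of 180 min, tested at 0.5 uM; a higher number here means that the compound lasts longer, a lower number that the compound disappears faster

compound 1 `CCC/N=C1\S/C(=C\c2ccc(OC(=O)C(C)(C)C)c(C)c2)C(=O)N1c1ccccc1C` with > 3 h as a limit of the assay
compound 2 `CCC/N=C1\S/C(=C\c2ccc(OC(=O)C(C)C)c(C)c2)C(=O)N1c1ccccc1C` with 0.35 h as a number

Going by the values given here, compound 2 with 0.35 h holds the only actual number so far in this assay. Among the compounds with values here, the one other value is a limit. The next compound is compound 3 `CCC/N=C1\S/C(=C\c2ccc(OC(=O)CCO)c(C)c2)C(=O)N1c1ccccc1C` and the change is 2-hydroxyethyl in place of isopropyl on a carbonyl carbon in words 2-hydroxyethyl in place of isopropyl on a carbonyl carbon. Within the data shown here, the one measured step that bears on this change alters the same group on that carbonyl carbon. It is an at least 8.5-fold lower number from compound 1 to compound 2 (0.93 log units; beyond the scatter) and it lies beyond the scatter. On that single step a further fall in half-life is expected, though its size is poorly fixed. The expected change is a 2.3-fold lower number from compound 2 to compound 3 (0.37 log units; beyond the scatter) as an estimate. For compound 3 the estimated half-life is 0.15 h with an expected range from 0.04 h to 0.5 h in this assay as the working figure.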

Compound 3, half-life: 0.137 h
Compound 3: the middle estimate sits 1.1-fold (0.04 log units) above what was measured; low and high end bracket the measured number.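

In this assay, the step of a 2.6-fold lower number from compound 2 to compound 3 (0.41 log units; beyond the scatter) has measured numbers at both ends, so this change on the carbonyl carbon gives a fixed size where the earlier step gave only a bound. Replacing the branched isopropyl with 2-hydroxyethyl extends the order seen so far at this position, and the full span across the three compounds is an at least 21-fold lower number from compound 1 to compound 3 (1.34 log units; beyond the scatter). Compound 1 remains a limit of the assay, so that span is a bound and not a measured size: the limit of > 3 h in this assay, at which 1 of the 3 values shown sits.

Going by these compounds, whether the fall at 2-hydroxyethyl follows the hydroxyl or the loss of branching stays open, and a straight propyl chain on the same carbonyl carbon would separate the two. On these data alone, an amine or a carboxylic acid at the end of that chain, or a cyclopropyl group in its place, also remains open.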